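The source may hold more compounds than are shown below. What is called first, only, known or untested is meant among the compounds shown, and "the series" means these compounds.

Values measured in a functional assay on BXPC-3 cells (Homo sapiens) for cytotoxicity, read by fluorescence, with a stated time of 48 h; a higher number here means that more compound is needed for the effect, a lower number that less compound is needed:

- compound 1 `CC(C)=CCC/C(C)=C/CC/C(C)=C/CSC[C@H](NC(=O)CCCCCN1CCN(C)CC1)C(=O)NC1CC1`: 6300 nM
- compound 2 `CC(C)=CCC/C(C)=C/CC/C(C)=C/CSC[C@H](NC(=O)CCCCCN1CCN(C)CC1)C(=O)N1CCCC1`: 3200 nM
- compound 3 `CC(C)=CCC/C(C)=C/CC/C(C)=C/CSC[C@H](NC(=O)CCCCCN1CCN(C)CC1)C(=O)N1CCCCC1`: 8800 nM

Compound 3 is clearly separated from only one of the other two compounds: a 2.8-fold higher number from compound 2 to compound 3 (0.44 log units; beyond the scatter). The other gap stays inside the normal noise of the measurement: a 1.4-fold higher number from compound 1 to compound 3 (0.15 log units; within the scatter).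

The next compound, compound 4 `CC(C)=CCC/C(C)=C/CC/C(C)=C/CSC[C@H](NC(=O)CCCCCN1CCN(C)CC1)C(=O)NC1CCCCC1`, has cyclohexylamino in place of piperidin-1-yl on a carbonyl carbon. Going by the values given here, no measured step makes exactly this change. The nearest guide is the step between compound 1, which carries cyclopropylamino, and compound 3, since it also links an amino group of this kind to piperidin-1-yl. That step is small: a 1.4-fold higher number from compound 1 to compound 3 (0.15 log units; within the scatter). Swapping cyclopropylamino for pyrrolidin-1-yl is also small: a 2.0-fold lower number from compound 1 to compound 2 (0.29 log units; within the scatter). On this evidence, no change beyond the scatter is expected in this assay. The expected step is a 1.5-fold lower number from compound 3 to compound 4 (0.17 log units; within the scatter). Compound 4 is estimated at 6000 nM, with an expected range of 2500 nM to 14000 nM.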

Compound 4, half-maximal effective concentration: 12000 nM
The estimate for compound 4 lay 2.0-fold (0.30 log units) below the measured number, and the stated range covers the measured number.
By their numbers in this assay, from the lowest: compounds 2, 1, 3 and 4 (each within the scatter of the next, the first and the last beyond it).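

Across this assay the swap of piperidin-1-yl for cyclohexylamino on a carbonyl carbon, which gives the amide nitrogen a hydrogen, stays within the scatter (a 1.4-fold higher number from compound 3 to compound 4 (0.13 log units; within the scatter)). Exchanging cyclopropyl for the larger cyclohexyl on an amide-type nitrogen also stays within it (a 1.9-fold higher number from compound 1 to compound 4 (0.28 log units; within the scatter)). Only compound 2, with pyrrolidin-1-yl, is set apart from the new compound (a 3.8-fold higher number from compound 2 to compound 4 (0.57 log units; beyond the scatter)), so the amide hydrogen alone does not sort these compounds: compound 1 and compound 4 carry it, while compound 2 and compound 3 lack it and still differ from each other.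

No supporting measurement here explains why pyrrolidin-1-yl stands apart. Also open, going by these compounds, is how a morpholin-4-yl ring, a benzylamino group or a carboxylic acid on this carbonyl carbon would compare.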